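The compounds below may be only part of what the source reports. "The series", "measured", "known", "first", "only" and "open" are said of these compounds alone.

Working notes on the series. Among the measured compounds shown here, in an ADME assay on the whole organism (plasma, Homo sapiens) for protein binding, read by LC-MS, with a stated time of 24 h (on this read-out higher numbers stand for a larger free fraction and lower numbers for a smaller free fraction), compound 1 `Cc1noc(-c2ccc(O[C@H]3CCC[C@H](C(=O)O)C3)cc2)c1COC(=O)N(C)CCC(C)C` gives 0.003, the lowest of the three numbers so far. Compound 2 `CN(C(=O)OCc1c(-c2ccc(O[C@H]3CCC[C@H](C(=O)O)C3)cc2)cnn1C)C1CCCC1` gives 0.009 and compound 3 `CN(C(=O)OCc1c(-c2ccc(O[C@H]3CCC[C@H](C(=O)O)C3)cc2)nnn1C)C1CCCC1` gives 0.033, both higher than compound 1 by more than the scatter. Compound 4 `Cc1noc(-c2ccc(O[C@H]3CCC[C@H](C(=O)O)C3)cc2)c1CNC(=O)OCCC(C)(C)C` keeps the core of compound 1 and changes one group: a group of 10 heavy atoms (7 carbon, 1 nitrogen, 2 oxygen; no ring) in place of a group of 10 heavy atoms (7 carbon, 1 nitrogen, 2 oxygen; no ring), on a saturated chain carbon bound to an aromatic carbon. The entering group has a hydrogen-bond donor that the leaving group lacks. For the measured compounds named here, no measured pair isolates a single change, so the expectation starts from compound 1 at 0.003: no step beyond the scatter in this assay, leaning slightly upward. The expected step is a 1.3-fold higher number from compound 1 to compound 4 (0.12 log units; within the scatter). For compound 4 the estimated value is 0.004, with an expected range of 0.002 to 0.01.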

Compound 4, unbound fraction: 0.006
Estimate against measurement, compound 4: 1.5-fold (0.18 log units) below, and the stated range covers the measured number.
By their numbers in this assay, from the lowest: compounds 1, 4 and 2 (each within the scatter of the next, the first and the last beyond it); then compound 3.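

In this assay, among the compounds shown here, the first change confined to one place gives a 2.0-fold higher number from compound 1 to compound 4 (0.30 log units; within the scatter). On a saturated chain carbon bound to an aromatic carbon, rejoining the same atoms into a group with a hydrogen-bond donor therefore does not separate the two compounds on this read-out. Nothing available explains the result. The compounds shown leave open whether an amine or a longer chain at this place would give a step beyond the scatter. They also leave open whether the same exchange would read alike on the core of compound 2 or compound 3.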